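A ring-bearing group replaces the fluorinated carbamate

This account rests on a few compounds, and the source may have more. Where it says the series, first, only, none or still open, it means among the compounds named here.

Going by the values given here, in a functional assay on isolated protein for inhibition of Glucose-dependent insulinotropic receptor (Rattus norvegicus), read by HTRF and cAMP accumulation (on this read-out higher numbers stand for larger maximal responses and lower numbers for smaller maximal responses), compound 1 `Cc1nc(S(C)(=O)=O)ccc1Oc1ncnc(OC2CCN(C(=O)O[C@@H](C)CF)CC2)c1F` gives 84%, and compound 2 `Cc1nc(S(C)(=O)=O)ccc1Oc1ncnc(OC2CCN(C(=O)O[C@@H](C)C(F)(F)F)CC2)c1F` gives 80%, the two numbers lying within the scatter of each other, as the only measured step, a number 4 percentage points lower from compound 1 to compound 2 (within the scatter), shows. Compound 3 `Cc1nc(S(C)(=O)=O)ccc1Oc1ncnc(OC2CCN(C(=S)OC3(C)CC3)CC2)c1F` differs from compound 2 by a group of 7 heavy atoms (5 carbon, 1 oxygen, 1 sulfur; one three-membered non-aromatic ring of carbon only) in place of a group of 9 heavy atoms (4 carbon, 2 oxygen, 3 fluorine; no ring), on an amine nitrogen in a ring. That single measured step concerns the same position but not this change, so nothing in the numbers points to a step beyond the scatter. Compound 3 is therefore expected to show a number 2 percentage points lower from compound 2 to compound 3 (within the scatter). The estimate for compound 3 is 78%, with a range from 60% to 95%.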

Compound 3, largest response reached (reported as efficacy), in percent of the reference or control that the assay uses: 49%
The estimate for compound 3 lay 29 percentage points above the measured number; measured number below the stated range.
By their numbers in this assay, from the lowest: compound 3; then compounds 2 and 1 (each within the scatter of the next).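

In this assay the substituent on the amine nitrogen of the six-membered ring proves able to move the maximal response: the group with the three-membered carbon ring and sulfur gives a number 31 percentage points lower from compound 2 to compound 3 (beyond the scatter) and a number 35 percentage points lower from compound 1 to compound 3 (beyond the scatter) while the earlier fluorine exchange on the chain stayed within the scatter. Nothing measured here accounts for this drop. The sulfur and the three-membered ring enter together, so the compounds shown leave open which of them goes with the loss. A (1-methylcyclopropoxy)carbonyl group, with oxygen in place of that sulfur, would separate the two.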